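Adding a fluoro to a growth-inhibiting compound

The source may hold more compounds than are shown below. What is called first, only, known or untested is meant among the compounds shown, and "the series" means these compounds.

Compound 1 `Cc1ccc2[nH]c(-c3ccc(-c4ccc(-c5cccc(Cl)c5)cc4)cc3)nc2c1`: 2780 nM
Compound 2 `Cc1ccc2[nH]c(-c3ccc(-c4ccc(-c5ccccc5)cc4)cc3)nc2c1`: 2560 nM

In a functional assay on COLO 205 cells (Homo sapiens) for inhibition, read by sulforhodamine B assay (on this read-out lower numbers stand for stronger inhibition of growth and higher numbers for weaker inhibition of growth), compound 2 gives 2560 nM, which cannot be told apart from the value of compound 1 once the usual scatter is considered. The next compound to be tested is compound 3 `Cc1ccc2[nH]c(-c3ccc(-c4ccc(-c5ccc(F)cc5)cc4)cc3)nc2c1`. It differs from compound 2 by one small change: fluoro in place of hydrogen on an aromatic carbon. This is a fluoro in place of hydrogen on an aromatic carbon, para to a large group.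

Among the compounds with values here, only one measured step bears on this change: a 1.1-fold lower number from compound 1 to compound 2 (0.04 log units; within the scatter). That step also swaps hydrogen and a halogen on an aromatic carbon, but the halogen is chloro rather than fluoro, so it is only a loose guide. It gives no reason to expect a real shift in this assay. The expected step is a 1.0-fold higher number from compound 2 to compound 3 (0.01 log units; within the scatter), which would lie within the scatter. The estimate for compound 3 is 2600 nM, with an expected range from 1400 nM to 4800 nM.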

Compound 3, concentration for 50% growth inhibition: 100000 nM
The estimate for compound 3 lay 38-fold (1.59 log units) below the measured number; measured number outside the range, above it.
By their numbers in this assay, from the lowest: compounds 2 and 1 (each within the scatter of the next); then compound 3.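

In this assay, replacing phenyl with 4-fluorophenyl gives a 39-fold higher number from compound 2 to compound 3 (1.59 log units; beyond the scatter), so adding one fluorine atom to this aromatic carbon can nearly abolish growth inhibition, a sensitivity that the earlier pair did not reveal. Replacing 3-chlorophenyl with 4-fluorophenyl gives a 36-fold higher number from compound 1 to compound 3 (1.56 log units; beyond the scatter), so this ring accepts the chloro of compound 1 without a real shift from compound 2, yet not the fluoro of compound 3, although these two compounds differ in both the halogen and its place on the ring. Nothing available explains the loss.

The compounds shown do not separate the effect of the halogen's identity from that of its place on the ring. They also leave open whether other groups on this same carbon, such as an amine or a carboxylic acid, would be tolerated.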